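The source may report more compounds than this note shows. Statements on the series, on what has been measured and on what is new or still open speak of the compounds shown alone.

Three compounds share one core and differ only in the group on the distal aromatic ring. Compound 1 `CC[C@H](C)[C@H](N)CN(C(=O)[C@@H]1C[C@H]1c1ccccc1)c1ccc(-c2ccc(C(C)(C)C)cc2)cc1` gives 750 nM in a functional assay for agonist activity at G protein-coupled receptor 88 (Homo sapiens), read by HTRF and cAMP accumulation (a higher number here means that more compound is needed for the effect, a lower number that less compound is needed), compound 2 `CC[C@H](C)[C@H](N)CN(C(=O)[C@@H]1C[C@H]1c1ccccc1)c1ccc(-c2ccc(C(F)(F)F)cc2)cc1` gives 340 nM, and compound 3 `CCOc1ccc(-c2ccc(N(C[C@@H](N)[C@@H](C)CC)C(=O)[C@@H]3C[C@H]3c3ccccc3)cc2)cc1` gives 90 nM. The steps run a 2.2-fold lower number from compound 1 to compound 2 (0.34 log units; beyond the scatter), an 8.3-fold lower number from compound 1 to compound 3 (0.92 log units; beyond the scatter) and a 3.8-fold lower number from compound 2 to compound 3 (0.58 log units; beyond the scatter), so compound 3 stands lowest of the three, with compound 2 nearest and compound 1 furthest. Compound 4 `CC[C@H](C)[C@H](N)CN(C(=O)[C@@H]1C[C@H]1c1ccccc1)c1ccc(-c2ccc(Oc3ccccc3)cc2)cc1` follows from compound 3 by phenyl in place of ethyl on an oxygen on an aromatic ring. Within the data shown here, none of the measured steps exchanges one group on that oxygen for another, so the measured steps bear only loosely on this change; they show that the identity of the distal group moves the number by modest amounts in either direction. Compound 4 is therefore expected at 200 nM, within 50 nM to 900 nM, a step of a 2.2-fold higher number from compound 3 to compound 4 (0.35 log units; beyond the scatter) that is expected to be modest.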

Compound 4, half-maximal effective concentration: 94 nM
Beside the measured number, compound 4's estimate is 2.1-fold (0.33 log units) above it; the range from low to high includes it.
By their numbers in this assay, from the lowest: compounds 3 and 4 (each within the scatter of the next); then compound 2; then compound 1.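

On the oxygen on an aromatic ring, phenyl in place of ethyl gives a 1.0-fold higher number from compound 3 to compound 4 (0.02 log units; within the scatter) and so brings six heavy atoms and an aromatic ring where ethyl has two heavy atoms, yet the two groups cannot be told apart here. Phenoxy, like ethoxy, stands clear of the other distal groups, with a 3.6-fold lower number from compound 2 to compound 4 (0.56 log units; beyond the scatter) and an 8.0-fold lower number from compound 1 to compound 4 (0.90 log units; beyond the scatter) for its exchange with trifluoromethyl and tert-butyl. Nothing at hand gives a reason for this match between the two groups on that oxygen. The compounds shown leave open how a longer chain such as butyl on that oxygen would read, and whether an amine in place of that oxygen would hold the number at this level.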